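This account rests on a few compounds, and the source may have more. Where it says the series, first, only, none or still open, it means among the compounds named here.

Compound 1 `COc1ccc(C(=O)/C=C/c2ccsc2)c2c1C=CC(C)(C)O2` was tested in a functional assay on K562 cells (Homo sapiens) for antiproliferative activity, read by MTT assay, with a stated time of 24 h; a lower number here means a stronger inhibitor, a higher number a weaker inhibitor. In this assay compound 1 gives only a limit, > 10000 nM, and not a number. Compound 2 `COc1ccc(C(=O)/C=C/c2cccc3ccccc23)c2c1C=CC(C)(C)O2` was tested in the same assay. Compound 2 likewise gives only a limit, > 10000 nM. Both results therefore sit at the limit of > 10000 nM in this assay, at which 2 of the 2 values shown sit, so compound 1 stands at that limit and nothing separates the two values. Compound 3 `COc1ccccc1/C=C/C(=O)c1ccc(OC)c2c1OC(C)(C)C=C2` differs from compound 1 in one place: 2-methoxyphenyl in place of thiophen-3-yl on a double-bonded chain carbon bound to a double-bonded chain carbon. No measured step of this kind exists among these compounds, so the size of this change in this assay is open. Compound 1 reaches only the limit > 10000 nM in this assay. The step from compound 1 to compound 3 is expected to be a step that the limit leaves unreadable from compound 1 to compound 3, no more than the usual scatter. Compound 3 is estimated at 15000 nM, within 4000 nM to 50000 nM, with a good chance that the assay again reports only a limit.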

Compound 3, half-maximal inhibitory concentration: > 10000 nM
Compound 3: no number, only a limit (the forecaster's own chance of this, stated with the estimate: 70%); the middle value does not contradict the limit.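

Compound 1 and compound 3 each give only a limit and not a number, so the step between them cannot be read. The compounds shown leave open what actual value any of them has in this assay, as all share one limit: the limit of > 10000 nM in this assay, at which 3 of the 3 values shown sit.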